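The source may report more compounds than this note shows. Statements on the series, on what has been measured and on what is new or still open speak of the compounds shown alone.

Of the compounds shown here, two have so far been measured in a functional assay on PC-3 cells (Homo sapiens) for cytotoxicity, read by MTT assay, with a stated time of 48 h; on this read-out lower numbers stand for stronger inhibition and higher numbers for weaker inhibition. Compound 1 `COc1cc(-c2nnc3n2NC(c2cccs2)C(C(=O)c2ccc(C)cc2)S3)cc(OC)c1OC` gives 5090 nM in this assay. Compound 2 `COc1cc(-c2nnc3n2NC(c2ccco2)C(C(=O)C2CC2)S3)cc(OC)c1OC` gives 95200 nM in this assay. Of these two numbers, compound 2 stands at the higher one, and the distance between compound 2 and compound 1 is beyond the scatter of the method. Going by the values given here, the two compounds differ from each other in more than one place, so no single step between them is set out.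

Compound 3 `COc1cccc(C(=O)C2Sc3nnc(-c4cc(OC)c(OC)c(OC)c4)n3NC2c2ccco2)c1` has not yet been measured. It differs from compound 2 in one place, (3-methoxyphenyl in place of cyclopropyl on a carbonyl carbon). Among the compounds with values here, the only measured compound that carries a six-membered aromatic ring on that carbonyl carbon is compound 1, which gives 5090 nM in this assay, far from the number of compound 2. On that basis the step is expected to be a clear fall, a 9.5-fold lower number from compound 2 to compound 3 (0.98 log units; beyond the scatter). Compound 3 is estimated at 10000 nM in this assay, with an expected range from 3000 nM to 40000 nM.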

Compound 3, half-maximal inhibitory concentration: 84600 nM
Beside the measured number, compound 3's estimate is 8.5-fold (0.93 log units) below it, outside the stated range (above it).
By their numbers in this assay, from the lowest: compound 1; then compounds 3 and 2 (each within the scatter of the next).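

In this assay, putting 3-methoxyphenyl in place of cyclopropyl on a carbonyl carbon gives a 1.1-fold lower number from compound 2 to compound 3 (0.05 log units; within the scatter), so the two groups cannot be told apart at this position, even though the entering group is much larger and brings a six-membered aromatic ring and a hydrogen-bond acceptor. Going by these compounds alone, this is the first reading of this position alone, as compound 1 and compound 2 differ in more than one place and their gap could not be assigned to any one of them; it now shows that a six-membered aromatic ring on that carbonyl carbon is not enough on its own to give a low number on the core of compound 3. No measured information on these compounds accounts for this result.

The compounds shown leave open whether a group of another kind on that carbonyl carbon, such as a dimethylamino group, a carboxylic acid or a longer chain like n-butyl, would separate from cyclopropyl and 3-methoxyphenyl. They also leave open whether the same swap would read the same way with a different group elsewhere on the shared core.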